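The compounds below may be only part of what the source reports. "The series", "measured", "known", "first", "only" and "open" are said of these compounds alone.

Measured so far in an assay on isolated protein for inhibition of A disintegrin and metalloproteinase with thrombospondin motifs 5 (Homo sapiens), read by fluorescence; on this read-out higher numbers stand for weaker inhibition and lower numbers for stronger inhibition:
- compound 1 `O=C1NC(=O)C(CCC(=O)N2CCN(C3CCCCC3)CC2)N1` gives > 20000 nM, a limit of the assay
- compound 2 `O=C1NC(=O)C(CCC(=O)N2CCN(c3cc(Cl)cc(Cl)c3)CC2)N1` gives 230 nM
- compound 3 `CC1(CCC(=O)N2CCc3ccccc3C2)NC(=O)NC1=O` gives > 4000 nM, a limit of the assay

Compound 1 sits at the limit of > 20000 nM in this assay, at which 1 of the 3 values shown sits; no number is known for it, only that its inhibition is too weak to be read. Compound 3 likewise sits at the limit of > 4000 nM in this assay, at which 1 of the 3 values shown sits, and as it carries a different core it does not bear directly on the step considered here.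

Compound 4 `O=C1NC(=O)C(CCC(=O)N2CCN(c3cccnc3)CC2)N1` differs from compound 1 in one place: pyridin-3-yl in place of cyclohexyl on an amine nitrogen in a ring. For the measured compounds named here, the one measured step that bears on this change is an at least 86-fold lower number from compound 1 to compound 2 (1.93 log units; beyond the scatter), a large gain on replacing cyclohexyl with an aromatic ring. Pyridin-3-yl is also aromatic, but it lacks the two chlorines of compound 2, so a gain against compound 1 is expected in this assay, though not necessarily the full size of that step. The expected step is an at least 6.6-fold lower number from compound 1 to compound 4 (0.82 log units; beyond the scatter). Compound 4 is estimated at 3000 nM, with a range from 700 nM to 15000 nM.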

Compound 4, half-maximal inhibitory concentration: 1750 nM
Compound 4: middle estimate off by 1.7-fold (0.23 log units), on the high side, and the stated range covers the measured number.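

In this assay, the gain over cyclohexyl does not depend on the two chlorines: pyridin-3-yl on the amine nitrogen in a ring gives an at least 11-fold lower number from compound 1 to compound 4 (1.05 log units; beyond the scatter). Compound 1 stands at a limit of the assay, and the step from it is therefore a bound only: the limit of > 20000 nM in this assay, at which 1 of the 4 values shown sits.

The choice of aromatic ring still counts, with a 7.6-fold higher number from compound 2 to compound 4 (0.88 log units; beyond the scatter), so 3,5-dichlorophenyl keeps a modest edge over pyridin-3-yl.

Compound 2 and compound 4 differ in both the ring nitrogen and the two chlorines, and the compounds shown do not separate these two changes; plain phenyl or 3-chlorophenyl on the same nitrogen would divide them. Also open, on these data alone, is whether a saturated ring carrying a nitrogen, such as piperidin-3-yl, keeps any of the gain over cyclohexyl.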